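A few compounds are considered here, and "the series" means these few. Any claim that something is new, unique, unknown or untested is made for them only; others in the source may bear on it.

Four compounds built on one shared core are compared for cytotoxicity. Compound 1 `CC(=O)c1ccc2[nH]c(-c3ccc(C(F)(F)F)cc3)nc2c1` was tested in an ADME assay on BHK-21 cells (Mesocricetus auratus) for cytotoxicity, read by MTT assay; on this read-out lower numbers stand for higher toxicity in this test and higher numbers for lower toxicity in this test; compound 1 gives > 100000 nM, which is a limit of the assay rather than a number. Compound 2 `CC(=O)c1ccc2c(c1)nc(-c1ccc(C(F)(F)F)cc1)n2C1CCCCC1` gives 33000 nM in this assay. The change hydrogen in place of cyclohexyl on an aromatic nitrogen brought an at least 3.0-fold higher number from compound 2 to compound 1 (0.48 log units; beyond the scatter). Compound 3 `C/C(=N\NC(N)=S)c1ccc2c(c1)nc(-c1ccoc1)n2C1CCCCC1` gives > 100000 nM in this assay, again only a limit of the assay. The difference between the cores of compound 2 and compound 3 is not broken down here. Compound 4 `C/C(=N\NC(N)=S)c1ccc2[nH]c(-c3ccoc3)nc2c1` remains to be measured; it differs from compound 3 by hydrogen in place of cyclohexyl on an aromatic nitrogen, the same kind of change as before, though here the place is next to the ring atom that bears a furan-3-yl group rather than a large group. Compound 4 is expected to show a step that the limit leaves unreadable from compound 3 to compound 4, because compound 3 already sits at the limit of > 100000 nM in this assay, at which 2 of the 3 values shown sit, and the measured at least 3.0-fold higher number from compound 2 to compound 1 (0.48 log units; beyond the scatter) ran toward lower toxicity. Compound 4 is therefore estimated at 150000 nM, with a likely range from 60000 nM to 400000 nM.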

Compound 4, half-maximal cytotoxic concentration: > 100000 nM
Compound 4 gave a limit, no number; the forecaster's own chance of this, stated with the estimate: 85%; the middle value is on the limit's open side.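

No step can be read from compound 3 to compound 4, because both stand at a limit of the assay, not at a number: the limit of > 100000 nM in this assay, at which 3 of the 4 values shown sit.

Going by these compounds, whether hydrogen in place of cyclohexyl changes the read-out in this assay for these two compounds stays open.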